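Spiro core series: aryl change at the imine carbon

The compounds below may be only part of what the source reports. "The series", "measured", "known", "first", "only" and "open" are said of these compounds alone.

Three compounds of the shared core have numbers in an assay on membranes from liver for displacement of a labelled ligand from Glucagon receptor (Mus musculus), read by scintillation counting, with a stated time of 60 min; on this read-out higher numbers stand for weaker inhibition and lower numbers for stronger inhibition. Compound 1 `C[C@H](c1ccc(C(=O)NCCC(=O)O)cc1)N1C(=O)C(c2cccc(C3CC3)c2)=N[C@]12CC[C@@H](C(C)(C)C)CC2` gives 1700 nM in this assay and stands second highest of the three. Compound 2 `CC(C)(C)[C@H]1CC[C@]2(CC1)N=C(c1cccc(C(F)(F)F)c1)C(=O)N2Cc1ccc(C(=O)NCCC(=O)O)cc1` gives 10000 nM in this assay, a number higher than that of compound 1 and beyond the scatter. Compound 3 `CC(C)(C)CC[C@H](c1ccc(C(=O)NCc2nn[nH]n2)cc1)N1C(=O)C(c2ccc(F)cc2)=N[C@]12CC[C@@H](C(C)(C)C)CC2` gives 90 nM in this assay, the lowest of the three and beyond the scatter from compound 1. Within the data shown here, no two of the measured compounds differ in only one place, so no single step is known.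

Compound 4 `C[C@H](c1ccc(C(=O)NCCC(=O)O)cc1)N1C(=O)C(c2ccccc2F)=N[C@]12CC[C@@H](C(C)(C)C)CC2` has not yet been measured. It differs from compound 1 in one place: 2-fluorophenyl in place of 3-cyclopropylphenyl on a carbon with a double bond to nitrogen. Nothing in the measured set isolates this exchange, so the size of the step is open. The expectation is a step toward a higher number, of a size near the edge of the scatter, a 1.8-fold higher number from compound 1 to compound 4 (0.25 log units; within the scatter) from compound 1 to compound 4. Compound 4 is therefore estimated at 3000 nM in this assay, with a range from 900 nM to 10000 nM.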

Compound 4, half-maximal inhibitory concentration: > 10000 nM
Compound 4 ended at the assay's limit (the forecaster's own chance of this, stated with the estimate: 10%); at least 3.3-fold (0.52 log units) between middle value and limit.
By their numbers in this assay, from the lowest: compound 3; then compound 1; then compound 2.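

In this assay, 2-fluorophenyl in place of 3-cyclopropylphenyl on a carbon with a double bond to nitrogen gives an at least 5.8-fold higher number from compound 1 to compound 4 (0.76 log units; beyond the scatter), the only single-place step shown for the series and one that lies beyond the scatter. Compound 4 gives > 10000 nM, which is a limit of the assay and not a number, so the step has a lower bound and its full size remains unread: the limit of > 10000 nM in this assay, at which 1 of the 4 values shown sits. On the shared core with the side chain of compound 1, this position is therefore not indifferent to the aryl group it carries, and 3-cyclopropylphenyl gives the lower number of the two groups compared.

The compounds shown leave open whether the step follows the loss of the cyclopropyl group or the arrival of the fluorine, a question that a plain phenyl group at this position would help to separate. Also open, from the compounds shown here alone, is whether the exchange behaves the same way with a tetrazole in place of the carboxylic acid, as compound 1 and compound 3 differ in more than one place.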